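This account rests on a few compounds, and the source may have more. Where it says the series, first, only, none or still open, it means among the compounds named here.

The three measured compounds share one core and differ only in the group on one aromatic carbon: compound 1 `COc1cc(C(O)(C(F)(F)F)C(F)(F)F)cnc1N1CCN(S(=O)(=O)c2ccc(N)nc2)CC1`, compound 2 `Nc1ccc(S(=O)(=O)N2CCN(c3ncc(C(O)(C(F)(F)F)C(F)(F)F)cc3C#CC3CC3)CC2)cn1` and compound 3 `Nc1ccc(S(=O)(=O)N2CCN(c3ncc(C(O)(C(F)(F)F)C(F)(F)F)cc3-c3ccncc3)CC2)cn1`. All were tested in an ADME assay (liver) for metabolic stability, with Liver microsome (Rattus norvegicus) as the target, using microsomes and NADPH, with a stated time of 30 min, tested at 1 uM; on this read-out lower numbers stand for slow clearance and higher numbers for fast clearance. As far as these compounds go, compound 1 reaches only a limit of the assay, < 14 mL.min-1.g-1, so its true number is unknown. Compound 2 gives 67 mL.min-1.g-1, while compound 3 gives 31 mL.min-1.g-1. Of the two exact numbers, compound 3 stands lowest; the gap to the nearest one is a 2.2-fold lower number from compound 2 to compound 3 (0.33 log units; beyond the scatter). Relative to the limit (the limit of < 14 mL.min-1.g-1 in this assay, at which 1 of the 3 values shown sits), both others move upward, shown by an at least 4.7-fold higher number from compound 1 to compound 2 (0.67 log units; beyond the scatter) and an at least 2.2-fold higher number from compound 1 to compound 3 (0.34 log units; beyond the scatter).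

Compound 4 `Nc1ccc(S(=O)(=O)N2CCN(c3ncc(C(O)(C(F)(F)F)C(F)(F)F)cc3-c3ccc4[nH]ncc4c3)CC2)cn1` has not been measured. It differs from compound 3 in one place: 1H-indazol-5-yl in place of pyridin-4-yl on an aromatic carbon. Within the data shown here, no measured step swaps one aromatic ring for a two-ring system, so none bears on this change directly; the two steps that alter this position move the number by modest amounts only. For compound 4 in this assay a small upward shift, a 1.4-fold higher number from compound 3 to compound 4 (0.13 log units; within the scatter), is expected. The estimate for compound 4 is 42 mL.min-1.g-1, between 20 mL.min-1.g-1 and 90 mL.min-1.g-1.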

Compound 4, intrinsic clearance in microsomes: 88 mL.min-1.g-1
Estimate against measurement, compound 4: 2.1-fold (0.32 log units) below; the measured number falls inside the stated range.
By their numbers in this assay, from the lowest: compound 3; then compounds 2 and 4 (each within the scatter of the next). At a limit, below all of these: compound 1.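

Replacing the single ring with a two-ring group at this position is not a neutral swap: in this assay, the 1H-indazol-5-yl gives a 2.8-fold higher number from compound 3 to compound 4 (0.45 log units; beyond the scatter), so two aromatic groups at the same carbon need not behave alike. Compound 4 also cannot be told apart from the alkyne-bearing compound 2, despite the very different shapes of their groups, as a 1.3-fold higher number from compound 2 to compound 4 (0.12 log units; within the scatter) shows. Methoxy still stands apart with an at least 6.2-fold higher number from compound 1 to compound 4 (0.79 log units; beyond the scatter), although this comparison rests on a limit, not a number: the limit of < 14 mL.min-1.g-1 in this assay, at which 1 of the 4 values shown sits.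

The compounds shown leave open whether the rise goes with the second ring or with the hydrogen-bond donor of the 1H-indazol-5-yl, a question that a naphthyl group could help to separate. They also leave open how an ethoxy group or a primary amine at this carbon would compare with methoxy.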